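Phenyl for cyclopropylmethyl on an amide-type nitrogen

A few compounds are considered here, and "the series" means these few. Any claim that something is new, unique, unknown or untested is made for them only; others in the source may bear on it.

In an ADME assay on microsomes from liver (Homo sapiens) for metabolic stability, with a stated time of 0.5 h (a lower number here means that less of the compound is left, a higher number that more of the compound is left), compound 1 (`CS(=O)(=O)c1c(CCc2ccccc2)c2cc(OCC(=O)NCC3CC3)ccc2[nH]c1=O`) stands at "not determined" (no result reported) and so offers no number to start from. The one measured reference in the series is compound 2 (`CC(C)(NC(=O)NCc1ccc2[nH]c(=O)c(-c3nccs3)c(CCc3ccccc3)c2c1)c1ccccc1`), which shows 40% in this assay and gives only a rough level for the series.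

Compound 3 (`CS(=O)(=O)c1c(CCc2ccccc2)c2cc(OCC(=O)Nc3ccccc3)ccc2[nH]c1=O`) keeps the core of compound 1 and changes in one place. The change is phenyl in place of cyclopropylmethyl on an amide-type nitrogen and puts phenyl in place of cyclopropylmethyl on an amide-type nitrogen. Among the measured compounds shown here, no measured step covers this change, so the data show neither its size nor its direction. The working expectation in this assay is therefore no step beyond the usual scatter, with no direction favoured, and the level is taken from compound 2 at 40% as the sole reference. The estimated value for compound 3 is 40% (expected range 15% to 70%).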

Compound 3, percent of the compound remaining: 67%
Estimate against measurement, compound 3: 27 percentage points below; low and high end bracket the measured number.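

No step can be read between compound 1 and compound 3 in this assay. The compounds shown leave open how far, and in which direction, phenyl in place of cyclopropylmethyl on an amide-type nitrogen shifts the percent remaining. No evidence on hand bears on this result.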